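The source may report more compounds than this note shows. Statements on the series, on what has been measured and on what is new or still open speak of the compounds shown alone.

Measured compounds:
compound 1 `COc1ccc(C(=O)Nc2nc3cc(C)cc(C)c3s2)cc1`: > 10 ug/mL
compound 2 `COc1ccc(NC(=O)Nc2nc3ccc(F)cc3s2)cc1`: > 10 ug/mL

In a functional assay on NUGC-3 cells (Homo sapiens) for antiproliferative activity, read by sulforhodamine B assay (a lower number here means a stronger inhibitor of growth, a higher number a weaker inhibitor of growth), compound 1 gives > 10 ug/mL, which is a limit of the assay and not a number. Compound 2 likewise reaches only a limit, > 10 ug/mL. Compound 1 therefore stands nowhere among ranked numbers; both values sit at the limit of > 10 ug/mL in this assay, at which 2 of the 2 values shown sit. Compound 3 `Cc1cc(C)c2sc(NC(=O)c3ccc([N+](=O)[O-])cc3)nc2c1` differs from compound 1 by nitro in place of methoxy on an aromatic carbon. Going by the values given here, no measured step is available to size this change; with both values at the limit, no shift beyond the scatter is expected in this assay. Compound 3 is estimated at 10 ug/mL, range 4 ug/mL to 30 ug/mL. The expected step is a number no higher from compound 1 to compound 3 (the limit leaves the size open).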

Compound 3, concentration for 50% growth inhibition: 1.32 ug/mL
For compound 3 the middle estimate is 7.6-fold (0.88 log units) above the measured one, outside the stated range (below it).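

In this assay, nitro in place of methoxy on an aromatic carbon para to a large group gives an at least 7.5-fold lower number from compound 1 to compound 3 (0.87 log units; beyond the scatter), so this position can move growth inhibition on the core of compound 1. Compound 3 carries a measured number, whereas the other compounds shown reach only a limit: the limit of > 10 ug/mL in this assay, at which 2 of the 3 values shown sit.

On these data alone, the true size of the step stays open, as the starting value is a limit. Also open, as far as these compounds go, is whether a nitrile, an amine or a carboxylic acid at this place would act as nitro does.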